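This account rests on a few compounds, and the source may have more. Where it says the series, first, only, none or still open, it means among the compounds named here.

Series notes. For the measured compounds named here, in a functional assay on MCF7 cells (Homo sapiens) for antiproliferative activity, read by CCK-8 assay, with a stated time of 72 h (a lower number here means a stronger inhibitor, a higher number a weaker inhibitor), compound 3 `COc1cccc(C(=O)Nc2cccc(-c3oc4cc(-c5ccc(F)cc5)ccc4c(=O)c3O)c2)c1` gives 15300 nM, the highest of the three numbers so far. Compound 2 `Cc1ccc(C(=O)Nc2cccc(-c3oc4cc(-c5ccc(F)cc5)ccc4c(=O)c3O)c2)cc1` gives 2400 nM, and compound 1 `O=C(Nc1cccc(-c2oc3cc(-c4ccc(F)cc4)ccc3c(=O)c2O)c1)c1ccc(F)cc1` gives 8590 nM. Going by the values given here, the steps of a 6.4-fold higher number from compound 2 to compound 3 (0.80 log units; beyond the scatter) and a 1.8-fold higher number from compound 1 to compound 3 (0.25 log units; within the scatter) set where compound 3 stands; the only other measured step is a 3.6-fold lower number from compound 1 to compound 2 (0.55 log units; beyond the scatter).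

Compound 4 `Cc1cc(C)cc(C(=O)Nc2cccc(-c3oc4cc(-c5ccc(F)cc5)ccc4c(=O)c3O)c2)c1` is not yet measured. It differs from compound 3 by 3,5-dimethylphenyl in place of 3-methoxyphenyl on a carbonyl carbon. The step bearing on it most directly is a 6.4-fold higher number from compound 2 to compound 3 (0.80 log units; beyond the scatter), read in reverse here, since compound 4 carries methyl groups on that aryl ring where compound 3 carries the methoxy group; the step of a 3.6-fold lower number from compound 1 to compound 2 (0.55 log units; beyond the scatter) also points toward a lower number when a methyl enters on an aromatic carbon of the series. A modest drop in this assay is therefore expected, of about the size of a 6.1-fold lower number from compound 3 to compound 4 (0.79 log units; beyond the scatter). For compound 4 the estimate in this assay is 2500 nM, with an expected range from 800 nM to 8000 nM.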

Compound 4, half-maximal inhibitory concentration: 20400 nM
Compound 4: middle estimate off by 8.2-fold (0.91 log units), on the low side, outside the stated range (above it).
By their numbers in this assay, from the lowest: compound 2; then compounds 1, 3 and 4 (each within the scatter of the next, the first and the last beyond it).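

In this assay, 3,5-dimethylphenyl in place of 3-methoxyphenyl on the carbonyl carbon gives a 1.3-fold higher number from compound 3 to compound 4 (0.12 log units; within the scatter), so methyl groups on this aryl ring do not by themselves go with a lower number. Compound 2, with its 4-methylphenyl group, stays apart, as an 8.5-fold higher number from compound 2 to compound 4 (0.93 log units; beyond the scatter) shows, and 3,5-dimethylphenyl in place of 4-fluorophenyl gives a 2.4-fold higher number from compound 1 to compound 4 (0.38 log units; beyond the scatter), a step that runs against the methyl-for-fluoro step seen earlier. Nothing on hand explains these steps.

The compounds shown leave open whether the lower number of compound 2 is specific to 4-methylphenyl or would persist with a longer chain, such as ethyl, or with an amine on that aryl ring. They also leave open whether the same order of aryl groups holds with a different group in place of the 4-fluorophenyl on the shared core.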